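The compounds below may be only part of what the source reports. "The series", "measured", "known", "first", "only" and "open" are said of these compounds alone.

Compound 1 `CN1CCN(CC(=O)Nc2nc3ccccc3[nH]2)CC1` and compound 2 `COc1ccc(N2CCN(CC(=O)Nc3nc4ccccc4[nH]3)CC2)cc1` share one core and differ at one amine nitrogen in a ring. In a functional assay, read by spectrophotometry, with a stated time of 30 min, tested at 25 ug/mL (a lower number here means a weaker effect, a higher number a stronger effect of the compound at the concentration tested), compound 1 gives 19.9%, and compound 2 gives 13.3%. Within the data shown here, the only measured step, a number 6.6 percentage points lower from compound 1 to compound 2 (within the scatter), is within the scatter. Of the two numbers shown, that of compound 2 is the lowest, but compound 1 sits within the scatter of it, so no real order between the two is established.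

Compound 3 `O=C(CN1CCN(c2ccc([N+](=O)[O-])cc2)CC1)Nc1nc2ccccc2[nH]1` differs from compound 2 by nitro in place of methoxy on an aromatic carbon. Among the measured compounds shown here, no measured step concerns this group; the one known step, a number 6.6 percentage points lower from compound 1 to compound 2 (within the scatter), touched a different part of the molecule and stayed within the scatter. With nothing to point in either direction, compound 3 is expected to show a step of a number 0.3 percentage points lower from compound 2 to compound 3 (within the scatter) that remains within the scatter. Compound 3 is therefore estimated at 13% in this assay, within a range from 3% to 28%.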

Compound 3, a percentage reported as activity, at one concentration (the size of the read-out at that concentration, not a potency): 33.9%
For compound 3 the middle estimate is 20.9 percentage points below the measured one; measured number outside the range, above it.
By their numbers in this assay, from the lowest: compounds 2 and 1 (each within the scatter of the next); then compound 3.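

In this assay, among these compounds, the substituent on the aromatic ring proves able to move the read-out: a number 20.6 percentage points higher from compound 2 to compound 3 (beyond the scatter) is the first step to clear the scatter, and it comes from nitro in place of methoxy. The step of a number 14 percentage points higher from compound 1 to compound 3 (beyond the scatter) also clears it, whereas 4-methoxyphenyl in place of methyl on the same amine nitrogen did not, so among these three compounds an aromatic ring at that nitrogen does not settle the outcome by itself; what it carries makes the difference. Nothing measured on these compounds explains why nitro and methoxy differ here.

Going by these compounds, it remains open whether this rise is particular to nitro or would also appear with a nitrile, a trifluoromethyl group or a carboxylic acid at the same place on the ring. The read-out comes from a single concentration. It shows a stronger or weaker effect at that concentration and leaves open how these compounds would compare at any other.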